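The source may report more compounds than this note shows. Statements on the series, on what has been measured and on what is new or still open speak of the compounds shown alone.

In a functional assay on the whole organism (strain Sprague-Dawley) for inhibition, with Rattus norvegicus as the target, with a stated time of 10 min (a higher number here means that more compound is needed for the effect, a lower number that less compound is needed), compound 1 (`O=C(O)c1cnc(-c2ccccc2Cl)[nH]c1=O`) gives 5 mg/kg, compound 2 (`CCOc1ccccc1-c1ncc(C(=O)O)c(=O)[nH]1`) gives 0.5 mg/kg, and compound 3 (`CCCCOc1ccccc1-c1ncc(C(=O)O)c(=O)[nH]1`) gives 0.5 mg/kg. Compound 3 thus stands level with compound 2, and together they hold the lowest of the three numbers. Ethoxy in place of chloro gave a 10-fold lower number from compound 1 to compound 2 (1.00 log units; beyond the scatter), and butoxy in place of chloro gave a 10-fold lower number from compound 1 to compound 3 (1.00 log units; beyond the scatter). Both of these steps exchange the chloro group itself, so they say little about a chain that is already in place.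

Compound 4 (`CCCCCOc1ccccc1-c1ncc(C(=O)O)c(=O)[nH]1`) differs from compound 3 by methyl in place of hydrogen on a saturated chain carbon, four bonds along the chain from an oxygen on an aromatic ring. Within the data shown here, the closest precedent is the chain extension with ethyl in place of hydrogen, which gave no change at the digits printed from compound 2 to compound 3 (within the scatter). On that basis, no step beyond the scatter is expected, and the expected outcome is no change at the digits printed from compound 3 to compound 4 (within the scatter). For compound 4 the estimated value is 0.5 mg/kg, with an expected range from 0.2 mg/kg to 2 mg/kg.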

Compound 4, dose for 50% inhibition: 3 mg/kg
The estimate for compound 4 lay 6.0-fold (0.78 log units) below the measured number; measured number above the stated range.
By their numbers in this assay, from the lowest: compounds 2 and 3 (each within the scatter of the next); then compounds 4 and 1 (each within the scatter of the next).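

In this assay, extending ethoxy to butoxy had changed nothing, but methyl in place of hydrogen on a saturated chain carbon, four bonds along the chain from an oxygen on an aromatic ring, gave a 6.0-fold higher number from compound 3 to compound 4 (0.78 log units; beyond the scatter) and so showed that this chain does respond to its length. The same holds against the shorter chain, with a 6.0-fold higher number from compound 2 to compound 4 (0.78 log units; beyond the scatter) as the step for propyl in place of hydrogen, while pentyloxy in place of chloro gave a 1.7-fold lower number from compound 1 to compound 4 (0.22 log units; within the scatter) and so kept none of the advantage over chloro that ethoxy and butoxy had shown. Nothing available explains this step.

Going by these compounds, whether the number keeps rising with a longer chain such as hexyloxy remains open. So does whether a chain of this length ending in a hydroxyl group or an amine would return to the level of compound 3.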